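From allyl to propargyl on a shared core

The source may report more compounds than this note shows. Statements on the series, on what has been measured and on what is new or still open speak of the compounds shown alone.

- compound 1 `N#Cc1c(-c2ccc(Cl)cc2)cc(-c2ccc(Cl)cc2)n(C(=O)c2ccccc2)c1=O` gives 3.75 ug/mL
- compound 2 `C=CCn1c(-c2ccc(Cl)cc2)cc(-c2ccc(Cl)cc2)c(C#N)c1=O` gives 20 ug/mL

Within the data shown here, of the two compounds measured in a functional assay on HepG2 cells (Homo sapiens) for cytotoxicity, read by sulforhodamine B assay, with a stated time of 48 h (on this read-out lower numbers stand for stronger inhibition and higher numbers for weaker inhibition), compound 2 carries the higher number and so the weaker inhibition, and compound 1 is its only neighbour. The next compound, compound 3 `C#CCn1c(-c2ccc(Cl)cc2)cc(-c2ccc(Cl)cc2)c(C#N)c1=O`, keeps the shared core and alters only the chain on the aromatic nitrogen: ethynyl in place of vinyl on a saturated chain carbon bound to an aromatic nitrogen. In words, this is ethynyl in place of vinyl on a saturated chain carbon bound to an aromatic nitrogen, or allyl to propargyl.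

Among the measured compounds shown here, one measured step bears on this, a 5.3-fold higher number from compound 1 to compound 2 (0.73 log units; beyond the scatter), and it lies beyond the scatter. For the measured compounds named here, that step is allyl in place of benzoyl on an aromatic nitrogen, a change of another kind, and no measured pair shows what ethynyl does in place of vinyl. As far as these compounds go, a step beyond the scatter is therefore not expected in this assay, and the direction stays open, with only a slight lean towards a lower number. The anchor is compound 2 at 20 ug/mL and nothing closer. Compound 3 is estimated at 15 ug/mL, with an expected range from 6 ug/mL to 35 ug/mL (both ends estimated). This estimate means a 1.3-fold lower number from compound 2 to compound 3 (0.12 log units; within the scatter), an expected step within the scatter.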

Compound 3, half-maximal inhibitory concentration: 18.3 ug/mL
For compound 3 the middle estimate is 1.2-fold (0.09 log units) below the measured one; the range from low to high includes it.
By their numbers in this assay, from the lowest: compound 1; then compounds 3 and 2 (each within the scatter of the next).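

In this assay, ethynyl in place of vinyl on a saturated chain carbon bound to an aromatic nitrogen gives a 1.1-fold lower number from compound 2 to compound 3 (0.04 log units; within the scatter), so allyl and propargyl cannot be told apart on this read-out, something the earlier pair, which differed by a change of another kind, could not show. Benzoyl on the aromatic nitrogen remains set apart from both chains: propargyl in its place gives a 4.9-fold higher number from compound 1 to compound 3 (0.69 log units; beyond the scatter), and allyl in its place gives a 5.3-fold higher number from compound 1 to compound 2 (0.73 log units; beyond the scatter), so both steps are beyond the scatter and both run towards a higher number. Nothing measured here accounts for either of these steps or for the lack of a step between the two chains.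

The compounds shown leave open whether a saturated chain such as propyl, or a longer chain ending in an amine or a carboxylic acid, would also stay within the scatter of compound 2 on this nitrogen. They also leave open whether the lower number of compound 1 is particular to benzoyl or would be shared by another acyl group, such as acetyl.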